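The source may hold more compounds than are shown below. What is called first, only, known or untested is meant among the compounds shown, and "the series" means these compounds.

Of the compounds shown here, three have so far been tested in a functional assay on B16 cells (Mus musculus) for cytotoxicity, read by MTT assay, with a stated time of 48 h; on this read-out higher numbers stand for weaker inhibition and lower numbers for stronger inhibition. Compound 1 `Cc1cccc(-c2cn(C[C@H]3COC(C)(C)O3)nn2)c1` gives only a limit of the assay there, > 100000 nM. Compound 2 `COc1ccc(C(O)c2cn(CCCO)nn2)cc1` likewise gives only a limit in this assay, > 100000 nM. Within the data shown here, compound 3 `CC1(C)OCC(Cn2cc(C(O)c3ccc4ccccc4c3)nn2)O1` is the one member that gives a number in this assay, 26900 nM. Compound 2 thus stands at the limit of > 100000 nM in this assay, at which 2 of the 3 values shown sit, so its true value in this assay is not known, only that it lies beyond the reported boundary.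

Compound 4 `COc1ccc(C(O)c2cn(Cc3cccc(OC)c3)nn2)cc1` differs from compound 2 in one place: 3-methoxyphenyl in place of 2-hydroxyethyl on a saturated chain carbon bound to an aromatic nitrogen. Everything else in compound 2 is kept. Among the measured compounds shown here, no step between two measured compounds of this set covers such a change, so the size of the step can only be guessed. For the measured compounds named here, the only measured number, that of compound 3, comes from the one compound carrying a second aromatic group on the chain bound to the aromatic nitrogen, which is the kind of group that enters in compound 4.

A downward step, from the limit into the range this assay reports, is therefore expected, though a further limit remains quite possible. The expected step is an at least 2.8-fold lower number from compound 2 to compound 4 (0.45 log units; beyond the scatter). Compound 4 is estimated at about 35000 nM, within a range from 8000 nM to 100000 nM.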

Compound 4, half-maximal inhibitory concentration: > 100000 nM
Compound 4: a limit, no number; the forecaster's own chance of this, stated with the estimate: 35%; middle value at least 2.8-fold (0.45 log units) from the limit.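

In this assay compound 2 and compound 4 both give only a limit, so no step can be read between them. Compound 4 joins compound 2 at the same boundary: the limit of > 100000 nM in this assay, at which 3 of the 4 values shown sit.

The compounds shown leave open how far each lies beyond that limit, and whether 3-methoxyphenyl in place of 2-hydroxyethyl changes the value at all.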